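Cytotoxicity of coumarin esters bearing an indole or isoquinoline arm

The compounds below may be only part of what the source reports. "The series", "measured", "known", "first", "only" and "open" are said of these compounds alone.

Measured compounds:
compound 1, `O=C(Oc1ccc2ccc(=O)oc2c1CN1CCc2ccccc2C1)c1ccccc1`, > 100000 nM
compound 2, `CCC(=O)Oc1ccc2ccc(=O)oc2c1Cc1c(-c2ccccc2)[nH]c2ccccc12`, > 100000 nM
compound 3, `CCC(=O)Oc1[nH]c2ccccc2c1Cc1c(OC(C)=O)ccc2ccc(=O)oc12`, 67000 nM

In an ADME assay on MT4 cells (Homo sapiens) for cytotoxicity, read by MTT assay, with a stated time of 96 h (a higher number here means that more compound is tolerated, a lower number that less compound is tolerated), compound 1 reaches only a limit of the assay, > 100000 nM. Compound 2 likewise reaches only a limit in this assay, > 100000 nM. Within the data shown here, compound 3 is the single compound with an actual number in this assay, 67000 nM, and it therefore stands alone. The two other values are limits, as described by the limit of > 100000 nM in this assay, at which 2 of the 3 values shown sit, so no ordering among the three can be drawn.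

Compound 4, `CC(=O)Oc1ccc2ccc(=O)oc2c1Cc1c(-c2ccccc2)[nH]c2ccccc12`, has not been measured. It differs from compound 3 by phenyl in place of propanoyloxy on an aromatic carbon. Compound 2 carries the same phenyl on the same five-membered ring and gives only a limit in this assay. On that basis compound 4 is expected to be tolerated at least as well as compound 3, with the step from compound 3 to compound 4 estimated at a 1.8-fold higher number from compound 3 to compound 4 (0.25 log units; within the scatter), in the direction of more compound tolerated, though it may not exceed the scatter. Compound 4 is estimated at 120000 nM, within 55000 nM to 300000 nM.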

Compound 4, half-maximal cytotoxic concentration: > 100000 nM
Compound 4 gave a limit, no number (the forecaster's own chance of this, stated with the estimate: 70%); the middle value does not contradict the limit.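

In this assay, among these compounds, this is the first one-place comparison at the aromatic carbon next to the ring nitrogen: phenyl in place of propanoyloxy gives an at least 1.4-fold higher number from compound 3 to compound 4 (0.17 log units; that floor lies within the scatter). Tolerance therefore does not fall measurably with this change, but the printed floor is too small to establish a real gain, and the phenyl compounds remain without a number: the limit of > 100000 nM in this assay, at which 3 of the 4 values shown sit. Changing the ester from propanoyloxy to the shorter acyl group of compound 4 cannot be assessed, as the step between compound 2 and compound 4 cannot be read from two limits.

From the compounds shown here alone, how far compound 4 lies beyond its limit remains open. So does whether an amine or a carboxylic acid at this place on the five-membered ring would give a measurable value.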